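This account rests on a few compounds, and the source may have more. Where it says the series, first, only, none or still open, it means among the compounds named here.

Measured in a functional assay on CAPAN-1 cells (Homo sapiens) for antiproliferative activity, with a stated time of 72 h; on this read-out higher numbers stand for weaker inhibition and lower numbers for stronger inhibition:
compound 1 `Nc1ncnn2c([C@@H]3O[C@H](CO)[C@@H](O)[C@H]3O)cc(-c3ccc(Cl)cc3)c12` gives 56700 nM
compound 2 `COc1ccc(-c2cc([C@@H]3O[C@H](CO)[C@@H](O)[C@H]3O)n3ncnc(N)c23)cc1` gives 43900 nM

Among the measured compounds shown here, compound 2 stands lowest of the two numbers, but its only neighbour, compound 1, lies within the scatter: a 1.3-fold lower number from compound 1 to compound 2 (0.11 log units; within the scatter). Compound 3 `Cc1ccccc1-c1cc([C@@H]2O[C@H](CO)[C@@H](O)[C@H]2O)n2ncnc(N)c12` carries a different aryl group: 2-methylphenyl in place of 4-methoxyphenyl on an aromatic carbon. For the measured compounds named here, the single measured step, a 1.3-fold lower number from compound 1 to compound 2 (0.11 log units; within the scatter), is the only one bearing on this change and it stayed within the scatter, so no movement beyond the scatter is expected here either, though the exchange of methoxy for methyl is not directly covered. Compound 3 is estimated at 45000 nM (range 15000 nM to 140000 nM), which means an expected step of a 1.0-fold higher number from compound 2 to compound 3 (0.01 log units; within the scatter).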

Compound 3, half-maximal inhibitory concentration: 97500 nM
Estimate against measurement, compound 3: 2.2-fold (0.34 log units) below; measured number inside the range.
By their numbers in this assay, from the lowest: compounds 2, 1 and 3 (each within the scatter of the next, the first and the last beyond it).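

Among the compounds shown here, the aryl position on the five-membered aromatic ring is not wholly flat: 2-methylphenyl in place of 4-methoxyphenyl gives the only step beyond the scatter so far, and a modest one (a 2.2-fold higher number from compound 2 to compound 3 (0.35 log units; beyond the scatter)). Against the 4-chlorophenyl group the same 2-methylphenyl stays within the scatter (a 1.7-fold higher number from compound 1 to compound 3 (0.24 log units; within the scatter)), so the separation rests on one pair. No measured evidence bears on this step. All three numbers remain high, and only substituted phenyl groups appear at this position. Going by these compounds, whether 4-methylphenyl, an amine or a carboxylic acid there would shift the number stays open.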